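Swapping a nitrobenzyl for a methylphenyl on a pyrazole acid

The source may hold more compounds than are shown below. What is called first, only, known or untested is meant among the compounds shown, and "the series" means these compounds.

Measured so far, in a functional assay on BJAB cells (Homo sapiens) for antiproliferative activity, with a stated time of 4 days; a higher number here means that more compound is needed for the effect, a lower number that less compound is needed:
- compound 1, `COc1cccc(-c2c(C)nn(-c3nc(-c4ccc(Cl)c(Cl)c4)c(SC(C)C)s3)c2C(=O)O)c1`: 14000 nM
- compound 2, `Cc1nn(-c2nc(-c3ccc(Cl)c(Cl)c3)c(SC(C)C)s2)c(C(=O)O)c1-c1ccccc1`: 3000 nM
- compound 3, `Cc1nn(-c2nc(-c3ccc(Cl)c(Cl)c3)c(SC(C)C)s2)c(C(=O)O)c1Cc1ccccc1[N+](=O)[O-]`: 20000 nM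

Compound 3 gives the highest of the three numbers; compound 1 is within the scatter of it, while compound 2 sits beyond the scatter, at a 6.7-fold higher number from compound 2 to compound 3 (0.82 log units; beyond the scatter).

Compound 4, `Cc1ccccc1-c1c(C)nn(-c2nc(-c3ccc(Cl)c(Cl)c3)c(SC(C)C)s2)c1C(=O)O`, differs from compound 3 in one place: 2-methylphenyl in place of 2-nitrobenzyl on an aromatic carbon. Among the measured compounds shown here, two measured steps bear on this change. The step of a 6.7-fold higher number from compound 2 to compound 3 (0.82 log units; beyond the scatter) shows that a phenyl ring bound directly to the core gives a markedly lower number than the 2-nitrobenzyl; compound 4 returns to a directly bound six-membered ring, which argues for a drop. Against that, the step of a 4.7-fold lower number from compound 1 to compound 2 (0.67 log units; beyond the scatter) shows that placing a group on that phenyl raised the number, and compound 4 carries a methyl on its ring. The step of a 1.4-fold higher number from compound 1 to compound 3 (0.15 log units; within the scatter) is within the scatter and adds little. On balance a drop is expected, but a smaller one than from compound 3 to compound 2, so the step from compound 3 to compound 4 is estimated at a 3.3-fold lower number from compound 3 to compound 4 (0.52 log units; beyond the scatter). Compound 4 is therefore expected to give about 6000 nM, most likely between 2000 nM and 20000 nM.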

Compound 4, half-maximal effective concentration: 5500 nM
Compound 4: the middle estimate sits 1.1-fold (0.04 log units) above what was measured; measured number inside the range.
By their numbers in this assay, from the lowest: compounds 2 and 4 (each within the scatter of the next); then compounds 1 and 3 (each within the scatter of the next).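

Moving to the directly bound 2-methylphenyl gives a 3.6-fold lower number from compound 3 to compound 4 (0.56 log units; beyond the scatter) in this assay, so this position can hold a substituted phenyl ring without the number reaching that of the 2-nitrobenzyl compound. Adding the methyl to the phenyl ring gives a 1.8-fold higher number from compound 2 to compound 4 (0.26 log units; within the scatter) and stays within the scatter, whereas the earlier compounds had only shown a methoxy-bearing ring with a number beyond the scatter of the plain phenyl, so a group on this ring does not always cost much. The change to 2-methylphenyl from 3-methoxyphenyl gives a 2.5-fold lower number from compound 1 to compound 4 (0.41 log units; beyond the scatter), which shows that the outcome depends on the group on the ring or on where it sits, although this pair cannot separate the two, and nothing available explains any of these differences.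

The compounds shown leave open whether the high number of compound 3 goes with the carbon link of its benzyl group or with its nitro group, and a plain benzyl group would tell these apart. They also leave open how 3-methylphenyl would compare with 2-methylphenyl, and whether an amine on the ring would be tolerated as well as a methyl.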